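Two Compounds at the Limit, a Third Expected to Follow

The source may hold more compounds than are shown below. What is called first, only, known or untested is meant among the compounds shown, and "the series" means these compounds.

The study examined cytotoxicity toward mouse fibroblasts using a toxicity assay on NIH3T3 cells (Mus musculus) for cytotoxicity, read by resazurin assay; on this read-out lower numbers stand for an effect already at smaller amounts and higher numbers for an effect only at larger amounts of compound. Compound 1 `CNC(=O)c1ccc(NCc2cncn2Cc2ccc(-c3ccccc3)cc2)cc1-c1ccccc1` gives > 1000 nM in this assay, which is a limit of the assay and not a measured number. Compound 2 `COC(=O)c1ccc(NCc2cncn2Cc2cccc(F)c2)cc1-c1ccccc1` likewise reports > 1000 nM in this assay, again a limit rather than a number. Among the measured compounds shown here, both results therefore rest at the limit of > 1000 nM in this assay, at which 2 of the 2 values shown sit, and the two values show only that neither compound reached a half-maximal effect within the tested range; no step between them can be sized, and nothing separates them in this assay.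

Compound 3 `COC(=O)c1ccc(NCc2cncn2Cc2ccc(C)cc2)cc1-c1ccccc1` is the next candidate. It differs from compound 2 in one place: 4-methylphenyl in place of 3-fluorophenyl on a saturated chain carbon bound to an aromatic nitrogen. For the measured compounds named here, no measured step of this kind exists in the set, so the size of the change cannot be read from the data. With compound 2 resting at a limit, the step is expected to be none beyond the scatter, and compound 3 is expected most likely to sit at the same limit. The expected step in this assay is a step that the limit leaves unreadable from compound 2 to compound 3. Compound 3 is estimated at 3000 nM, with a range from 1000 nM to 10000 nM.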

Compound 3, half-maximal effective concentration: 50000 nM
Estimate against measurement, compound 3: 17-fold (1.22 log units) below, outside the stated range (above it).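

No step can be read from compound 2 to compound 3, for the result of compound 2 in this assay is a limit and not a number: the limit of > 1000 nM in this assay, at which 2 of the 3 values shown sit.

The compounds shown leave open where the value of compound 2 lies, and with it the size of the change from 3-fluorophenyl to 4-methylphenyl in this assay.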